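A few compounds are considered here, and "the series" means these few. Any claim that something is new, unique, unknown or untested is made for them only; others in the source may bear on it.

Measured compounds:
compound 1, `CC(O)(CSc1cccc(C(F)(F)F)c1)C(=O)Nc1cc(C(F)(F)F)cc(C(F)(F)F)c1`: 9670 nM
compound 2, `CC(O)(CSc1ccccc1C(F)(F)F)C(=O)Nc1cc(C(F)(F)F)cc(C(F)(F)F)c1`: 4370 nM
compound 3, `CC(O)(CS(=O)(=O)c1cccc(C(F)(F)F)c1)C(=O)Nc1cc(C(F)(F)F)cc(C(F)(F)F)c1`: 10300 nM

In a functional assay on CWR22R cells (Homo sapiens) for antiproliferative activity, read by fluorescence and propidium iodide staining, with a stated time of 96 h (a lower number here means a stronger inhibitor, a higher number a weaker inhibitor), compound 1 gives 9670 nM, compound 2 gives 4370 nM and compound 3 gives 10300 nM. Compound 1 and compound 2 differ in one place, (2-(trifluoromethyl)phenyl in place of 3-(trifluoromethyl)phenyl on a sulfur). This change made a 2.2-fold lower number from compound 1 to compound 2 (0.34 log units; beyond the scatter). Compound 3 and compound 1 differ in more than one place, and the difference between the two cores is not broken down here; their two numbers lie within the scatter of each other, while compound 2 shows a lower number than compound 3.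

Compound 4, `CC(O)(CS(=O)(=O)c1ccccc1C(F)(F)F)C(=O)Nc1cc(C(F)(F)F)cc(C(F)(F)F)c1`, has not yet been measured in this assay. It differs from compound 3 as follows: 2-(trifluoromethyl)phenyl in place of 3-(trifluoromethyl)phenyl on a sulfonyl sulfur. Within the data shown here, this is the same kind of change as the one from compound 1 to compound 2, though the surroundings differ: in compound 3 the group sits on a sulfonyl sulfur whose other neighbours are a saturated chain carbon, whereas in compound 1 it sits on a sulfur whose other neighbours are a saturated chain carbon. A step of similar size is expected for compound 4, namely a 2.1-fold lower number from compound 3 to compound 4 (0.33 log units; beyond the scatter), because the same change gave a 2.2-fold lower number from compound 1 to compound 2 (0.34 log units; beyond the scatter). The estimate for compound 4 in this assay is 4800 nM, expected to fall between 2400 nM and 9600 nM.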

Compound 4, half-maximal inhibitory concentration: 9450 nM
The estimate for compound 4 lay 2.0-fold (0.29 log units) below the measured number, and the stated range covers the measured number.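

In this assay, 2-(trifluoromethyl)phenyl in place of 3-(trifluoromethyl)phenyl on a sulfonyl sulfur gives a 1.1-fold lower number from compound 3 to compound 4 (0.04 log units; within the scatter), so on this core the change leaves no readable difference. Set beside the step on the core of compound 1, where the group sits on a sulfur, the two results do not differ by more than two such steps can scatter: the same change on two cores in this assay, a 2.2-fold lower number (0.34 log units; beyond the scatter) from compound 1 to compound 2 and a 1.1-fold lower number (0.04 log units; within the scatter) from compound 3 to compound 4, 2.0-fold (0.31 log units) apart, within the scatter of two such steps This shows that the two cores are compatible with one shared effect of the change, but it does not show that the effect is the same on both, nor that the core plays no part, as it rests on one pair of compounds per core in a single assay.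

The compounds shown leave open how a phenyl carrying a nitrile or a chlorine in place of trifluoromethyl would behave on either core. They also leave open whether the same change would read alike with a sulfoxide or an ether oxygen in place of the sulfur.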